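Swapping Fluoro for Methyl at the Cytotoxicity Limit

The compounds below may be only part of what the source reports. "The series", "measured", "known", "first", "only" and "open" are said of these compounds alone.

In a functional assay on MT4 cells (Homo sapiens) for cytotoxicity, read by MTT assay, with a stated time of 5 days (a lower number here means that less compound is tolerated, a higher number that more compound is tolerated), compound 1 (`N#Cc1ccc(Nc2nccc(Oc3ccc(-c4ccc(C#N)cc4)c(F)c3)n2)cc1`) gives > 307000 nM, which is a limit and not a number. Compound 2 (`N#Cc1ccc(Nc2nccc(Oc3ccc(-c4ccc(C#N)cc4)c(F)c3F)n2)cc1`) gives > 294000 nM, which is also a limit. Among the compounds with values here, the only measured step near this change is a step that the two limits leave unreadable from compound 1 to compound 2, with fluoro in place of hydrogen on an aromatic carbon, so it offers no size to carry forward.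

Compound 3 (`Cc1cc(Oc2ccnc(Nc3ccc(C#N)cc3)n2)ccc1-c1ccc(C#N)cc1`) differs from compound 1 by methyl in place of fluoro on an aromatic carbon, ortho to a 4-cyanophenyl group: methyl in place of fluoro on an aromatic carbon. Within the data shown here, no measured step covers this exchange, and the data show no number for how far this assay responds to any change. With compound 1 at > 307000 nM, the expectation is that no step beyond the scatter will appear, and that the result may again be a limit. The expected change is an at least 1.0-fold lower number from compound 1 to compound 3 (0.01 log units; that floor lies within the scatter), with no direction favoured by the data. For compound 3, the estimated half-maximal cytotoxic concentration is 300000 nM, with an expected range of 80000 nM to 320000 nM.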

Compound 3, half-maximal cytotoxic concentration: 29400 nM
The estimate for compound 3 lay 10-fold (1.01 log units) above the measured number; the measured number lies below the stated range.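

Within the data shown here, the exchange of methyl for fluoro on an aromatic carbon, ortho to a 4-cyanophenyl group, gives an at least 10-fold lower number from compound 1 to compound 3 (1.01 log units; beyond the scatter) in this assay, the first step in these compounds with any readable size. Compound 3, at 29400 nM, is the only compound shown with a number and not a limit, so this assay does respond to a change at this position, with less of compound 3 tolerated. Compound 1 stands only at a limit, so the step has a known floor and no known full size: the limit of > 307000 nM in this assay, at which 1 of the 3 values shown sits.

The compounds shown leave open whether the drop belongs to methyl itself or would also follow from another group on this carbon, such as an ethyl, a methoxy or an amine. They also leave open whether a methyl would act in the same way on the carbon that carries the second fluoro in compound 2, where the step from compound 1 cannot be read.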